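Thiophen-3-yl for phenyl on two nucleoside cores

A few compounds are considered here, and "the series" means these few. Any claim that something is new, unique, unknown or untested is made for them only; others in the source may bear on it.

Compound 2 `Nc1nc(N)c2c(-c3ccccc3)cn([C@@H]3O[C@H](CO)[C@@H](O)[C@H]3O)c2n1` carries a phenyl on the shared core, and compound 1 `Nc1nc(N)c2c(-c3ccsc3)cn([C@@H]3O[C@H](CO)[C@@H](O)[C@H]3O)c2n1` is the same core with thiophen-3-yl in place of phenyl, the difference counted as thiophen-3-yl in place of phenyl on an aromatic carbon. In a functional assay on HepG2 cells (Homo sapiens) for antiproliferative activity, read by XTT assay, with a stated time of 72 h (a higher number here means a weaker inhibitor, a lower number a stronger inhibitor), compound 2 gives only a limit, > 20000 nM. In this assay compound 1 likewise gives only a limit, > 20000 nM. The step that the two limits leave unreadable from compound 2 to compound 1 therefore has no readable size; both values sit at the limit of > 20000 nM in this assay, at which 3 of the 3 values shown sit.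

Compound 3 `Nc1nc2c(c(-c3ccccc3)cn2[C@@H]2O[C@H](CO)[C@@H](O)[C@H]2O)c(=O)[nH]1` carries the same phenyl on a second core; the difference between the two cores is not broken down here. In this assay compound 3 again gives only a limit, > 20000 nM.

Compound 4 `Nc1nc2c(c(-c3ccsc3)cn2[C@@H]2O[C@H](CO)[C@@H](O)[C@H]2O)c(=O)[nH]1`, not yet measured, is compound 3 with thiophen-3-yl in place of phenyl, counted as thiophen-3-yl in place of phenyl on an aromatic carbon. The surroundings of the place are described in the same words as for the change from compound 2 to compound 1, so this is the same change made a second time.

For compound 4 the step that the limit leaves unreadable from compound 3 to compound 4 is expected to be as unreadable in size as a step that the two limits leave unreadable from compound 2 to compound 1 in this assay, an expectation that rests on all three measured values sitting at the limit of > 20000 nM in this assay, at which 3 of the 3 values shown sit. Compound 4 is accordingly estimated at 30000 nM in this assay, with an expected range from 15000 nM to 100000 nM, and most probably only a limit will be reported once more.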

Compound 4, half-maximal inhibitory concentration: > 20000 nM
Compound 4: a limit, no number; the forecaster's own chance of this, stated with the estimate: 85%; the middle value lies beyond the limit too.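

In this assay compound 4 gives > 20000 nM, again a limit and not a number. No size can therefore be read for the step from compound 3 to compound 4, nor for the same change from compound 2 to compound 1. The compounds shown leave open whether thiophen-3-yl in place of phenyl, or the choice of core, alters activity at all, as every value sits at one limit: the limit of > 20000 nM in this assay, at which 4 of the 4 values shown sit.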